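Thiophene-carboxamide thioureas: ortho-methyl for ortho-trifluoromethyl

A few compounds are considered here, and "the series" means these few. Any claim that something is new, unique, unknown or untested is made for them only; others in the source may bear on it.

Compound 1 `NC(=O)c1c(NC(=O)c2ccccc2Br)sc2c1CCN(C(=S)Nc1ccccc1C(F)(F)F)C2` gives, in a functional assay on HeLa cells (Homo sapiens) for antiproliferative activity, with a stated time of 24 h (on this read-out lower numbers stand for stronger inhibition and higher numbers for weaker inhibition), a half-maximal inhibitory concentration of 39600 nM. Compound 2 `Cc1ccccc1NC(=S)N1CCc2c(sc(NC(=O)c3ccccc3Br)c2C(N)=O)C1` reaches only the assay limit of > 50000 nM in this assay. The change between them, (methyl in place of trifluoromethyl on an aromatic carbon), shows up as an at least 1.2-fold higher number from compound 1 to compound 2 (0.10 log units; that floor lies within the scatter); that the step is read as a floor rests on (the limit of > 50000 nM in this assay, at which 2 of the 3 values shown sit).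

Compound 3 `NC(=O)c1c(NC(=O)c2ccccc2C(F)(F)F)sc2c1CCN(C(=S)Nc1ccccc1Br)C2` likewise returns only the limit of > 50000 nM in this assay. The difference between the cores of compound 1 and compound 3 is not broken down here. Compound 4 `Cc1ccccc1C(=O)Nc1sc2c(c1C(N)=O)CCN(C(=S)Nc1ccccc1Br)C2` is not yet measured; it differs from compound 3 by methyl in place of trifluoromethyl on an aromatic carbon, the same change as that from compound 1 to compound 2.

Since compound 3 sits at the limit > 50000 nM and the earlier step, an at least 1.2-fold higher number from compound 1 to compound 2 (0.10 log units; that floor lies within the scatter), went toward weaker inhibition, compound 4 is expected to move by a step that the limit leaves unreadable from compound 3 to compound 4. The estimate for compound 4 is 70000 nM, between 30000 nM and 200000 nM, most likely again only a limit.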

Compound 4, half-maximal inhibitory concentration: > 50000 nM
Compound 4 ended at the assay's limit; the forecaster's own chance of this, stated with the estimate: 75%; the middle value does not contradict the limit.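

Compound 3 and compound 4 both stand at a limit, so no step between them can be read: the limit of > 50000 nM in this assay, at which 3 of the 4 values shown sit.

The compounds shown leave open whether methyl in place of trifluoromethyl changes inhibition at all in this pair.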